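The source may hold more compounds than are shown below. What is called first, only, known or untested is meant among the compounds shown, and "the series" means these compounds.

Measured so far:
- compound 1 `Nc1nc(O)nc2c1nc(O)n2Cc1ccccc1` — 1 mg/kg
- compound 2 `Nc1nc(SCc2ccccc2)nc2c1nc(O)n2Cc1ccccc1` — a limit of > 1 mg/kg
- compound 3 `CCCOc1nc(N)c2nc(O)n(Cc3ccccc3)c2n1` — 0.3 mg/kg

In a functional assay on the whole organism for activation, with Mus musculus as the target (a higher number here means that more compound is needed for the effect, a lower number that less compound is needed), compound 1 gives 1 mg/kg. Compound 2 gives no number in this assay, only the limit > 1 mg/kg. Compound 3 gives 0.3 mg/kg. The steps read a number no lower from compound 1 to compound 2 (the limit leaves the size open), a 3.3-fold lower number from compound 1 to compound 3 (0.52 log units; beyond the scatter) and an at least 3.3-fold lower number from compound 2 to compound 3 (0.52 log units; beyond the scatter). For the measured compounds named here, compound 2 thus stands at the limit of > 1 mg/kg in this assay, at which 1 of the 3 values shown sits, and no number is known for it; only the step to compound 3 is readable, as a lower bound on its size.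

Compound 4 `CSc1nc(N)c2nc(O)n(Cc3ccccc3)c2n1` is not yet measured. Relative to compound 2 the change is hydrogen in place of phenyl on a saturated chain carbon bound to a sulfur. Going by the values given here, the step bearing on it is the one from compound 2 to compound 3, where the whole benzylsulfanyl gave way to propoxy and the number fell at least modestly; here only the phenyl is removed and the sulfur kept, so a smaller move is expected. A drop from the limit of compound 2 is expected, a number no higher from compound 2 to compound 4 (the limit leaves the size open), with compound 4 estimated at 1 mg/kg, range 0.3 mg/kg to 3 mg/kg.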

Compound 4, minimum effective dose: 0.1 mg/kg
Estimate against measurement, compound 4: 10-fold (1.00 log units) above; the whole stated range lies above it.
By their numbers in this assay, from the lowest: compound 4; then compound 3; then compound 1.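

In this assay, taking only the phenyl off the benzylsulfanyl group while keeping the sulfur gives an at least 10-fold lower number from compound 2 to compound 4 (1.00 log units; beyond the scatter), so a sulfur on this aromatic carbon does not by itself hold the number up. Methylsulfanyl also reads better than the other groups on this carbon, with a 3.0-fold lower number from compound 3 to compound 4 (0.48 log units; beyond the scatter) against propoxy and a 10-fold lower number from compound 1 to compound 4 (1.00 log units; beyond the scatter) against hydroxy, which leaves compound 4 with the lowest number of the series. Going by these compounds, the size of the step out of compound 2 stays open-ended, as that compound is known only by a limit: (the limit of > 1 mg/kg in this assay, at which 1 of the 4 values shown sits).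

Methylsulfanyl and propoxy differ in both the linking atom and the chain, so the compounds shown do not separate these two changes. On these data alone, how an ethylsulfanyl chain or an amine on this aromatic carbon would read remains open.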